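The compounds below may be only part of what the source reports. "The series", "measured", "known", "first", "only" and "open" are said of these compounds alone.

Measured so far:
compound 1 `CC1=C(C(=O)Nc2ccc(C)cc2)C(c2cn(-c3ccccc3)nc2-c2ccccc2)NC(=O)N1` — 71700 nM
compound 2 `CC1=C(C(=O)Nc2ccc(C)cc2)C(c2cn(-c3ccccc3)nc2-c2ccccc2)NC(=S)N1` — 56100 nM

Both were run in a functional assay on MCF7 cells (Homo sapiens) for inhibition, read by sulforhodamine B assay, with a stated time of 24 h; on this read-out lower numbers stand for stronger inhibition of growth and higher numbers for weaker inhibition of growth. Compound 2 gives the lower of the two numbers, but compound 1 sits within the scatter of it, so no order between them can be claimed.

Compound 3 `CC1=C(C(=O)Nc2ccccc2Cl)C(c2cn(-c3ccccc3)nc2-c2ccccc2)NC(=S)N1` is not yet measured. It differs from compound 2 by 2-chlorophenyl in place of 4-methylphenyl on an amide-type nitrogen. Within the data shown here, no measured pair shows this kind of exchange, so nothing in the set tells the direction. The step of a 1.1-fold lower number from compound 2 to compound 3 (0.05 log units; within the scatter) is therefore expected to be small, not beyond the scatter. Compound 3 is expected at about 50000 nM, in the range 20000 nM to 150000 nM.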

Compound 3, concentration for 50% growth inhibition: 68800 nM
The estimate for compound 3 lay 1.4-fold (0.14 log units) below the measured number, within the range that was stated.
By their numbers in this assay, from the lowest: compounds 2, 3 and 1 (each within the scatter of the next).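

In this assay, among these compounds, the first exchange at this amide-type nitrogen, 2-chlorophenyl in place of 4-methylphenyl, gives a 1.2-fold higher number from compound 2 to compound 3 (0.09 log units; within the scatter), so these two groups cannot be told apart on this read-out. The position therefore tolerates this swap of one aromatic carbon-only ring for another without a readable change. No measurement of any property of these groups accompanies the result.

Open, on these data alone, is whether a carboxylic acid, an amine or a longer alkyl chain at this nitrogen would move the number beyond the scatter. Also open, as far as these compounds go, is how 2-chlorophenyl reads on the core of compound 1.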